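Methyl in Place of Methoxy on the Aryl Group

This account rests on a few compounds, and the source may have more. Where it says the series, first, only, none or still open, it means among the compounds named here.

compound 1 `Cc1ccc(C)c(/C=C/[C@](C)(O)CC[C@@H]2[C@@]3(C)CCCC(C)(C)[C@@H]3CC[C@@]2(C)O)c1`: 3380 nM
compound 2 `CC1(C)CCC[C@]2(C)[C@@H](CC[C@@](C)(O)/C=C/c3cncc4ccccc34)[C@](C)(O)CC[C@@H]12`: 46000 nM
compound 3 `COc1cccc(OC)c1/C=C/[C@](C)(O)CC[C@@H]1[C@@]2(C)CCCC(C)(C)[C@@H]2CC[C@@]1(C)O`: 48200 nM

In a functional assay on HeLa cells (Homo sapiens) for cytotoxicity, read by MTT assay, with a stated time of 48 h (on this read-out lower numbers stand for stronger inhibition and higher numbers for weaker inhibition), compound 3 gives the highest of the three numbers; compound 2 lies within the scatter of it, while compound 1 stands far apart, as a 14-fold higher number from compound 1 to compound 3 (1.15 log units; beyond the scatter) shows. Compound 4 `Cc1cccc(C)c1/C=C/[C@](C)(O)CC[C@@H]1[C@@]2(C)CCCC(C)(C)[C@@H]2CC[C@@]1(C)O` differs from compound 3 in one place: 2,6-dimethylphenyl in place of 2,6-dimethoxyphenyl on a double-bonded chain carbon bound to a double-bonded chain carbon. The measured step that bears on this is a 14-fold higher number from compound 1 to compound 3 (1.15 log units; beyond the scatter), a large rise when a dimethoxyphenyl took the place of a dimethylphenyl. Compound 4 reverses a change of that kind, although its group is 2,6-dimethylphenyl and not the 2,5-dimethylphenyl of compound 1, so the return need not be complete. A large downward step is therefore expected, an 8.0-fold lower number from compound 3 to compound 4 (0.90 log units; beyond the scatter). Compound 4 is estimated at 6000 nM, with a range from 2000 nM to 20000 nM.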

Compound 4, half-maximal inhibitory concentration: 3460 nM
Compound 4: middle estimate off by 1.7-fold (0.24 log units), on the high side, and the stated range covers the measured number.
By their numbers in this assay, from the lowest: compounds 1 and 4 (each within the scatter of the next); then compounds 2 and 3 (each within the scatter of the next).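

Among the aryl groups, 2,6-dimethylphenyl and 2,5-dimethylphenyl cannot be told apart, with a 1.0-fold higher number from compound 1 to compound 4 (0.01 log units; within the scatter). By contrast, 2,6-dimethylphenyl separates clearly from the other two groups, with a 14-fold lower number from compound 3 to compound 4 (1.14 log units; beyond the scatter) and a 13-fold lower number from compound 2 to compound 4 (1.12 log units; beyond the scatter), so among these compounds the choice of group matters more here than the arrangement of the two methyl groups. Nothing given here explains these steps. On these data alone, what remains open is how a phenyl carrying an amine or a carboxylic acid would behave on this double-bonded chain carbon.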